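The compounds below may be only part of what the source reports. "The series", "measured", "known", "first", "only" and "open" are said of these compounds alone.

Three compounds have been measured in a functional assay on the whole organism (strain STD-dd) with Mus musculus as the target, in the maximal electroshock model, with a stated time of 2 h; a lower number here means that less compound is needed, a higher number that more compound is needed for the effect:

Compound 1 `CN1CCN(S(=O)(=O)Cc2noc3ccccc23)CC1`: 57 mg/kg
Compound 2 `NS(=O)(=O)Cc1noc2ccc(F)cc12`: 15 mg/kg
Compound 3 `CCNS(=O)(=O)Cc1noc2ccc(F)cc12`: 32 mg/kg

Among these three numbers, compound 3 stands second highest. Its nearest neighbour is compound 1, whose number is higher but within the scatter, so the two cannot be told apart. Its furthest neighbour is compound 2, whose number is lower by a step beyond the scatter, as the measured step of a 2.1-fold higher number from compound 2 to compound 3 (0.33 log units; beyond the scatter) shows.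

The next compound, compound 4 `CN1CCN(S(=O)(=O)Cc2noc3ccc(F)cc23)CC1`, is reached from compound 3 by a single change: 4-methylpiperazin-1-yl in place of ethylamino on a sulfonyl sulfur. For the measured compounds named here, only one measured step bears on this change, and only loosely: a 2.1-fold higher number from compound 2 to compound 3 (0.33 log units; beyond the scatter) shows that making the group on the sulfonamide nitrogen larger gave a modestly higher number. Going by the values given here, compound 1 carries the same 4-methylpiperazin-1-yl on its sulfonyl sulfur as compound 4 but lacks the fluorine, and no measured step tells what that fluorine alone does. A modest rise in the number is therefore expected, a 1.6-fold higher number from compound 3 to compound 4 (0.19 log units; within the scatter), pointing towards the value of compound 1. Compound 4 is estimated at 50 mg/kg, with a range from 25 mg/kg to 100 mg/kg.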

Compound 4, dose for half-maximal effect: 100 mg/kg
Beside the measured number, compound 4's estimate is 2.0-fold (0.30 log units) below it; the measured number falls inside the stated range.
By their numbers in this assay, from the lowest: compound 2; then compounds 3, 1 and 4 (each within the scatter of the next, the first and the last beyond it).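

On the shared fluorinated core, the group on the sulfonyl sulfur now has a third member, and 4-methylpiperazin-1-yl needs clearly more compound for the effect in this assay than either smaller group (a 3.1-fold higher number from compound 3 to compound 4 (0.49 log units; beyond the scatter); a 6.7-fold higher number from compound 2 to compound 4 (0.82 log units; beyond the scatter)). Together with the earlier step from amino to ethylamino, these three compounds rise in order as the group on the sulfur grows, a pattern that holds only for these three. For the compounds shown here, the pair of compound 1 and compound 4 also isolates fluoro in place of hydrogen on an aromatic carbon for the first time, and that change cannot be told apart from the scatter (a 1.8-fold higher number from compound 1 to compound 4 (0.24 log units; within the scatter)), while nothing measured here explains either result.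

The compounds shown leave open whether a morpholine, a piperidine or a small dimethylamino group on the sulfonyl sulfur would fall nearer to amino or to 4-methylpiperazin-1-yl. They also leave open whether fluoro makes any more difference when the sulfur carries amino, and whether chlorine or methoxy on that aromatic carbon would behave as fluoro does.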